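Trading Methylsulfonyl for 5-Methoxypyridin-2-yl on the Shared Core

A few compounds are considered here, and "the series" means these few. Any claim that something is new, unique, unknown or untested is made for them only; others in the source may bear on it.

Compound 1 `O=C(CCCCCCc1ccccc1)c1nncs1` gives > 10000 nM in an assay on HEK-293T cells for inhibition of diacylglycerol lipase-alpha (Homo sapiens), read by colorimetric assay (a higher number here means a weaker inhibitor, a lower number a stronger inhibitor), which is a limit of the assay rather than a number.
Compound 2 `O=C(CCCCCCc1ccccc1)c1nnc(-c2ccco2)s1` gives > 10000 nM, also a limit.
Compound 3 `CS(=O)(=O)c1cnc(C(=O)CCCCCCc2ccccc2)o1` gives > 10000 nM, again a limit.

Because every value sits at the limit of > 10000 nM in this assay, at which 3 of the 3 values shown sit, the step that the two limits leave unreadable from compound 1 to compound 2 cannot be read, and compound 3 stands only at that limit with no number of its own. Compound 4 `COc1ccc(-c2cnc(C(=O)CCCCCCc3ccccc3)o2)nc1` differs from compound 3 by 5-methoxypyridin-2-yl in place of methylsulfonyl on an aromatic carbon. Within the data shown here, no measured step involves this change or the core of compound 3, and the one measured step is unreadable, so no direction or size can be foreseen. Compound 4 is therefore estimated at 8000 nM (range 1500 nM to 30000 nM), an expected step of an at least 1.2-fold lower number from compound 3 to compound 4 (0.09 log units; that floor lies within the scatter).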

Compound 4, half-maximal inhibitory concentration: > 10000 nM
Compound 4: only a limit was reported (the forecaster's own chance of this, stated with the estimate: 60%); middle value at least 1.2-fold (0.09 log units) from the limit.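

Compound 3 and compound 4 both stop at a limit of the assay, not at a number, so no step between them can be read: the limit of > 10000 nM in this assay, at which 4 of the 4 values shown sit.

The compounds shown leave open whether any change on these cores would give a measurable number.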